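Sulfur Linker in Place of an Ether on the Core

This account rests on a few compounds, and the source may have more. Where it says the series, first, only, none or still open, it means among the compounds named here.

For the measured compounds named here, compound 1 `Nc1cc(N)c2nc(-c3ccccc3)c(Oc3ccc(Cl)c(Cl)c3)nc2c1` is the only compound of this set that has a number: in a functional assay on NCI-H522 cells (Homo sapiens) for inhibition, read by sulforhodamine B assay, with a stated time of 48 h (on this read-out higher numbers stand for weaker inhibition of growth and lower numbers for stronger inhibition of growth), compound 1 gives 33900 nM. Compound 2 `CCOC(=O)[C@H](CCC(=O)O)NC(=O)c1ccc(CNc2nc3cc(N)cc(N)c3nc2-c2ccccc2)cc1` reaches only a limit of the assay, giving < 100000 nM in this assay. Compound 3 `CCOC(=O)[C@H](CCC(=O)O)NC(=O)c1ccc(Sc2nc3cc(N)cc(N)c3nc2-c2ccccc2)cc1` likewise reaches only a limit, giving < 100000 nM in this assay. Because of the limit of < 100000 nM in this assay, at which 2 of the 3 values shown sit, compound 1 stands alone as the anchor for what follows. Compound 4 `Nc1cc(N)c2nc(-c3ccccc3)c(Sc3ccc(Cl)c(Cl)c3)nc2c1` differs from compound 1 in one place: (3,4-dichlorophenyl)sulfanyl in place of 3,4-dichlorophenoxy on an aromatic carbon. Going by the values given here, no pair of measured compounds shows this exchange, so its effect is open. The author expects the step of a 1.2-fold lower number from compound 1 to compound 4 (0.08 log units; within the scatter) to stay within the usual scatter, with no clear direction. Compound 4 is therefore estimated at 28000 nM, between 9000 nM and 90000 nM.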

Compound 4, concentration for total growth inhibition: 33900 nM
Compound 4: the middle estimate sits 1.2-fold (0.08 log units) below what was measured; the measured number falls inside the stated range.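

The exchange of 3,4-dichlorophenoxy for (3,4-dichlorophenyl)sulfanyl on the aromatic carbon next to the ring nitrogen gives no change at the digits printed from compound 1 to compound 4 (within the scatter) in this assay. For the compounds shown here, this is the first reading of such a linker exchange at this position, and on this read-out the oxygen and sulfur linkers cannot be told apart. Compound 2 and compound 3 add no second reading of it: the limit of < 100000 nM in this assay, at which 2 of the 4 values shown sit.

Still open, on these data alone, is whether a sulfonyl linker or a longer chain, such as an ethylene linker, at this position would keep the value of compound 1.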